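Swapping chloro for bromo on a chalcone-like acetate

The source may report more compounds than this note shows. Statements on the series, on what has been measured and on what is new or still open speak of the compounds shown alone.

Compound 1 `CC(=O)OC/C(=C\c1ccccc1Br)C(=O)c1ccccc1`: 17000 nM
Compound 2 `CC(=O)OC/C(=C/c1ccccc1Cl)C(=O)c1ccccc1`: 19000 nM

In a functional assay on T47D cells (Homo sapiens) for inhibition, read by sulforhodamine B assay, with a stated time of 48 h (a higher number here means a weaker inhibitor of growth, a lower number a stronger inhibitor of growth), compound 2 gives 19000 nM, and compound 1 gives 17000 nM; the two numbers sit within the scatter of each other, so neither compound can be called the stronger. Compound 3 `CC(=O)OC/C(=C/c1ccccc1Br)C(=O)c1ccccc1` carries bromo in place of chloro on an aromatic carbon. Within the data shown here, with no measured pair that isolates this exchange, the expected step from compound 2 to compound 3 in this assay is small in either direction, not beyond the scatter, estimated as a 1.1-fold lower number from compound 2 to compound 3 (0.05 log units; within the scatter). Compound 3 is therefore expected to give about 17000 nM, between 8000 nM and 40000 nM.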

Compound 3, concentration for 50% growth inhibition: 18000 nM
The estimate for compound 3 lay 1.1-fold (0.02 log units) below the measured number; the measured number falls inside the stated range.
By their numbers in this assay, from the lowest: compounds 1, 3 and 2 (each within the scatter of the next).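

Now that the double bond is drawn the same way in both compounds, the exchange of 2-chlorophenyl for 2-bromophenyl can be read on its own, as a 1.1-fold lower number from compound 2 to compound 3 (0.02 log units; within the scatter). The drawn configuration of the double bond can also be read on its own, as a 1.1-fold higher number from compound 1 to compound 3 (0.02 log units; within the scatter). That second reading rests on a single clean pair: the fact that compounds 1 and 3 differ only in the configuration as drawn

On these data alone, whether an amine or a carboxylic acid on this aromatic carbon would give a step beyond the scatter stays open. So does the effect of a longer chain in place of the acetate.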